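The source may report more compounds than this note shows. Statements on the series, on what has been measured and on what is new or still open speak of the compounds shown alone.

In a functional assay on A549 cells (Homo sapiens) for cytotoxicity, read by XTT assay, with a stated time of 72 h (on this read-out lower numbers stand for stronger inhibition and higher numbers for weaker inhibition), compound 1 `COc1ccc(C(=O)c2cc(OC)c(OC)c(OC)c2)cc1[N+](=O)[O-]`, which carries a nitro group, gives > 10000 nM, a limit of the assay and not a number. Compound 3 `CCn1ccc2cc(Cc3ccc(OC)c(OC)c3OC)ccc21` gives > 10000 nM, again only a limit. For the measured compounds named here, compound 2 `COc1ccc(Cc2ccc(OC)c(OC)c2OC)cc1N` gives 2700 nM, the only true number so far, so it has no measured value to be ranked against.

Compound 4 `COc1ccc(Cc2ccc(OC)c(OC)c2OC)cc1[N+](=O)[O-]` differs from compound 2 at one place: nitro in place of amino on an aromatic carbon, ortho to a methoxy group and meta to a large group (nitro in place of amino on an aromatic carbon). Going by the values given here, no measured pair shows this exchange, so the size of the step in this assay is not known. Among the compounds with values here, the only guide is compound 1, also a nitro compound, with its limit of > 10000 nM. This points weakly toward weaker inhibition. The expected step of a 3.3-fold higher number from compound 2 to compound 4 (0.52 log units; beyond the scatter) is therefore modest but beyond the usual scatter, and the assay may report only a limit. For compound 4 the estimated value is 9000 nM, with an expected range of 3000 nM to 25000 nM.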

Compound 4, half-maximal inhibitory concentration: > 10000 nM
Compound 4: only a limit was reported; the forecaster's own chance of this, stated with the estimate: 55%; middle value at least 1.1-fold (0.04 log units) from the limit.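

Nitro in place of amino on an aromatic carbon, ortho to a methoxy group, gives an at least 3.7-fold higher number from compound 2 to compound 4 (0.56 log units; beyond the scatter) in this assay. For the compounds shown here, this is the first single-place change, and it shows that the true number held by compound 2 does not survive this exchange at this position. The step is only a floor, since compound 4 gives a limit of the assay and not a number, and its true size cannot be read: the limit of > 10000 nM in this assay, at which 3 of the 4 values shown sit.

Going by these compounds, how far compound 4 actually lies from compound 2 remains open. Also open is whether the amino group itself is needed at this position, as the compounds shown give no reading for a hydroxyl, a methylamino or an acetamide group there, or for a plain hydrogen.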